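Swapping trifluoromethyl for a fluorinated isopropyl on the amide

The source may report more compounds than this note shows. Statements on the series, on what has been measured and on what is new or still open speak of the compounds shown alone.

In a functional assay on isolated protein for inhibition of Glucose-dependent insulinotropic receptor (Homo sapiens), read by HTRF and cAMP accumulation (a lower number here means that less compound is needed, a higher number that more compound is needed for the effect), compound 1 `Cc1nc(S(C)(=O)=O)ccc1Oc1ncnc(OC2CCN(C(=O)OC(C)C)CC2)c1F` gives 21 nM. Going by the values given here, compound 2 `Cc1nc(S(C)(=O)=O)ccc1Oc1ncnc(OC2CCN(C(=O)C(F)(F)F)CC2)c1F` carries a trifluoromethyl on the carbonyl carbon in place of the isopropoxy, and in this assay compound 2 gives 151 nM; of the two numbers so far it is the higher one, the only measured step being a 7.2-fold higher number from compound 1 to compound 2 (0.86 log units; beyond the scatter). Compound 3 `Cc1nc(S(C)(=O)=O)ccc1Oc1ncnc(OC2CCN(C(=O)C(C)(C)F)CC2)c1F` alters that same position once more: 1-fluoro-1-methylethyl in place of trifluoromethyl on a carbonyl carbon. Among the compounds with values here, only the one measured step bears on this change; it was modest and beyond the scatter, showing that the group on this carbonyl carbon matters. The entering group shares the three-carbon branching of the isopropoxy of compound 1 while keeping one fluorine of compound 2. The expected outcome is therefore a fall in this assay that stops short of the number for compound 1, namely a 3.0-fold lower number from compound 2 to compound 3 (0.48 log units; beyond the scatter). Compound 3 is estimated at 50 nM, within a range from 15 nM to 160 nM.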

Compound 3, half-maximal effective concentration: 76.3 nM
Beside the measured number, compound 3's estimate is 1.5-fold (0.18 log units) below it; low and high end bracket the measured number.
By their numbers in this assay, from the lowest: compound 1; then compounds 3 and 2 (each within the scatter of the next).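

In this assay, putting 1-fluoro-1-methylethyl in place of trifluoromethyl on the carbonyl carbon gives a 2.0-fold lower number from compound 2 to compound 3 (0.30 log units; within the scatter), so these two groups cannot be told apart here, although one carries three fluorines and the other one fluorine and three carbons. The isopropoxy group stays separate from the new group, with a 3.6-fold higher number from compound 1 to compound 3 (0.56 log units; beyond the scatter), so the earlier gap to compound 1 is not particular to trifluoromethyl: both groups that replace isopropoxy give higher numbers than compound 1 does. No measurement shown here explains this difference.

Still open, on these data alone, is whether the oxygen of the isopropoxy group or its overall shape accounts for the gap. An unfluorinated isopropyl group or a tert-butoxy group on the same carbonyl carbon would bear on this question.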